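Compound 4 against the limit of compound 3

The source may report more compounds than this note shows. Statements on the series, on what has been measured and on what is new or still open speak of the compounds shown alone.

Values in a functional assay on cells (Platelet, Homo sapiens) for inhibition; on this read-out lower numbers stand for stronger inhibition and higher numbers for weaker inhibition:
- compound 1 `COC(=O)c1ccc(-c2nn(Cc3ccccc3)c3ccccc23)cc1` gives 560 nM
- compound 2 `CC(C)OC(=O)c1ccc(-c2nn(Cc3ccccc3)c3ccccc23)cc1` gives > 10000 nM as a limit
- compound 3 `CNC(=O)c1ccc(-c2nn(Cc3ccccc3)c3ccccc23)cc1` gives > 10000 nM as a limit

Compound 3 sits at the limit of > 10000 nM in this assay, at which 2 of the 3 values shown sit, and so has a limit rather than a number of its own.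

Compound 4 `CO/N=C\c1ccc(-c2nn(Cc3ccccc3)c3ccccc23)cc1` is reached from compound 3 by a group of 4 heavy atoms (2 carbon, 1 nitrogen, 1 oxygen; no ring) in place of a group of 4 heavy atoms (2 carbon, 1 nitrogen, 1 oxygen; no ring), on an aromatic carbon on the carbon para to a large group, with methylcarbamoyl leaving.

Among the measured compounds shown here, two measured steps bear on this, and both are large: an at least 17-fold higher number from compound 1 to compound 3 (1.25 log units; beyond the scatter) and an at least 17-fold higher number from compound 1 to compound 2 (1.25 log units; beyond the scatter). Among these three compounds, only compound 1 gives a number, and both changes to its ester end at the limit. Compound 4 gives up the methylcarbamoyl of compound 3, so some recovery toward compound 1 at 560 nM is expected. Compound 2 warns against counting on this, since a small change there already reached the limit.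

For compound 4 the expected step is to a lower number, estimated as an at least 3.3-fold lower number from compound 3 to compound 4 (0.52 log units; beyond the scatter) in this assay. For compound 4 the estimated value is 3000 nM with an expected range from 600 nM to 15000 nM and a further limit reading remains possible.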

Compound 4, half-maximal inhibitory concentration: > 10000 nM
Compound 4: no number, only a limit (the forecaster's own chance of this, stated with the estimate: 40%); middle value at least 3.3-fold (0.52 log units) away from the limit.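

In this assay compound 4 gives > 10000 nM, which is a limit and not a number. With 0 hydrogen-bond donors in the entering group against 1 in methylcarbamoyl, the loss of the amide hydrogen does not bring back a readable value at this aromatic carbon, and the change leaves an at least 17-fold higher number from compound 1 to compound 4 (1.25 log units; beyond the scatter). The steps from compound 2 and from compound 3 to compound 4 cannot be read, and among the groups shown at this position only the one in compound 1 gives a number, the rest ending at one shared ceiling: the limit of > 10000 nM in this assay, at which 3 of the 4 values shown sit.

Going by these compounds, how far compound 2, compound 3 and compound 4 lie beyond that limit stays unknown, so no order can be given among them. Also open, on these data alone, is whether an ethyl ester or a carboxylic acid at this position would give a number.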